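This account rests on a few compounds, and the source may have more. Where it says the series, first, only, none or still open, it means among the compounds named here.

Measured so far: compound 1 `CC(C)c1cccc(C(C)C)c1OC(=O)NC(=O)OCc1ccccc1` with 77 nM in an assay on microsomes from intestine for inhibition of acyl-CoA:cholesterol acyltransferase (Oryctolagus cuniculus); a lower number here means a stronger inhibitor, a higher number a weaker inhibitor; compound 2 `CC(C)c1cccc(C(C)C)c1OC(=O)NC(=O)OCCCc1ccccc1` with 660 nM.

Among these two numbers compound 1 stands lowest, compound 2 giving an 8.6-fold higher number from compound 1 to compound 2 (0.93 log units; beyond the scatter). Compound 3 `CC(C)c1cccc(C(C)C)c1OC(=O)NC(=O)SCCc1ccccc1` is not yet measured. It differs from compound 1 in one place: phenethylsulfanyl in place of benzyloxy on a carbonyl carbon. Among the compounds with values here, the only measured step, that from compound 1 to compound 2, bears on this change only in part: it, too, lengthens what separates the phenyl ring from the carbonyl, and it raised the number modestly. Nothing measured speaks to the exchange of oxygen for sulfur on the carbonyl carbon. Compound 3 is therefore expected to give a somewhat higher number than compound 1, with a 3.2-fold higher number from compound 1 to compound 3 (0.51 log units; beyond the scatter) estimated, but not as high as compound 2. The estimate for compound 3 in this assay is 250 nM, expected to fall between 70 nM and 900 nM.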

Compound 3, half-maximal inhibitory concentration: 880 nM
Compound 3: the middle estimate sits 3.5-fold (0.55 log units) below what was measured; measured number inside the range.
By their numbers in this assay, from the lowest: compound 1; then compounds 2 and 3 (each within the scatter of the next).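

In this assay, phenethylsulfanyl on this carbonyl carbon, whose other neighbour is an amide-type nitrogen, is clearly less well accepted than benzyloxy, with an 11-fold higher number from compound 1 to compound 3 (1.06 log units; beyond the scatter). Compound 2 with 660 nM and compound 3 with 880 nM lie within the scatter of each other, so both of the changed groups leave compound 1 alone at the low end of the three numbers. No measurement at hand accounts for this rise.

Going by these compounds, this change alters the linking atom and the chain together, so the share of each remains open; a benzylsulfanyl group or a phenethyloxy group on the same carbonyl carbon would separate them. Also open, on these data alone, is how an amine or a carboxylic acid on the phenyl ring of the benzyloxy group would read in this assay.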